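The source may report more compounds than this note shows. Statements on the series, on what has been measured and on what is new or still open speak of the compounds shown alone.

Working notes on the series. In a functional assay on Hep cells (Homo sapiens) for cytotoxicity, read by sulforhodamine B assay, with a stated time of 48 h (on this read-out lower numbers stand for stronger inhibition and higher numbers for weaker inhibition), compound 1 (`C=CCOc1c(Cl)cccc1C(=O)c1cccnc1`) gives 92000 nM and compound 2 (`C=CCOc1ccc(Br)cc1C(=O)c1cccnc1`) gives 78000 nM. These two values lie within the scatter of each other, so compound 1 cannot be ranked against compound 2, and both stand on the same level.

Compound 3 (`C=CCOc1c(Cl)cc(Cl)cc1C(=O)c1cccnc1`) has not yet been measured in this assay. It differs from compound 1 in one place: chloro in place of hydrogen on an aromatic carbon. The incoming chloro group replaces hydrogen on an aromatic carbon, meta to a chloro group and para to an allyloxy group.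

Among the measured compounds shown here, no step between measured compounds that differ in one place is available, so this change has no direct precedent. For the measured compounds named here, the only guide is compound 2, which at 78000 nM stays within the scatter of compound 1. A small move towards a lower number is expected, with no shift beyond the scatter. The expected 1.5-fold lower number from compound 1 to compound 3 (0.19 log units; within the scatter) reflects this. The estimated value for compound 3 is 60000 nM, with an expected range of 25000 nM to 130000 nM.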

Compound 3, half-maximal inhibitory concentration: > 100000 nM
Compound 3: a limit, no number; the forecaster's own chance of this, stated with the estimate: 15%; at least 1.6-fold (0.22 log units) between middle value and limit.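

In this assay compound 3 gives > 100000 nM, which is a limit of the assay and not a number. Chloro in place of hydrogen on this aromatic carbon, meta to a chloro group and para to an allyloxy group, does not bring the lower number that was open before this reading. The change reads as an at least 1.0-fold higher number from compound 1 to compound 3 (0.03 log units; that floor lies within the scatter), so this position shows no gain from the added chloro, while the floor of the step stays within the scatter and no loss can be claimed: the limit of > 100000 nM in this assay, at which 1 of the 3 values shown sits.

On these data alone, the true size of the step remains open, as the reading gives a floor and nothing more. Also open, as far as these compounds go, is whether an amine or a carboxylic acid at this same position would move the number down into the readable range of this assay, and whether a longer chain in place of the allyloxy group would do so.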